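From Amide to Carbamoylcarbonylmethyl on the Amine Nitrogen

This account rests on a few compounds, and the source may have more. Where it says the series, first, only, none or still open, it means among the compounds named here.

Compound 1 `Cc1cn([C@@H]2O[C@H](CO[Si](C)(C)C(C)(C)C)[C@@]3(OS(=O)(=O)C=C3NC(=O)c3ccccc3)[C@H]2O[Si](C)(C)C(C)(C)C)c(=O)n(C)c1=O` gives 9700 nM in a functional assay on HEL cells (Homo sapiens); on this read-out higher numbers stand for lower toxicity in this test and lower numbers for higher toxicity in this test.
Compound 2 `COC(=O)C(=O)CNC1=CS(=O)(=O)O[C@@]12[C@@H](CO[Si](C)(C)C(C)(C)C)O[C@@H](n1cc(C)c(=O)n(C)c1=O)[C@@H]2O[Si](C)(C)C(C)(C)C` reaches only the limit > 200000 nM in this assay.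
Compound 3 `COC(=O)CC(=O)NC1=CS(=O)(=O)O[C@@]12[C@@H](CO[Si](C)(C)C(C)(C)C)O[C@@H](n1cc(C)c(=O)n(C)c1=O)[C@@H]2O[Si](C)(C)C(C)(C)C` gives 29000 nM in this assay.

Compound 3 stands highest of the two plain numbers; the gap to the other number is a 3.0-fold higher number from compound 1 to compound 3 (0.48 log units; beyond the scatter). Compound 4 `Cc1cn([C@@H]2O[C@H](CO[Si](C)(C)C(C)(C)C)[C@@]3(OS(=O)(=O)C=C3NCC(=O)C(N)=O)[C@H]2O[Si](C)(C)C(C)(C)C)c(=O)n(C)c1=O` differs from compound 3 in one place: (carbamoylcarbonyl)methyl in place of ((methoxycarbonyl)methyl)carbonyl on an amine nitrogen. Going by the values given here, two measured steps bear on this. The closest is an at least 6.8-fold lower number from compound 2 to compound 3 (0.83 log units; beyond the scatter), where a methyl bearing a carbonyl on the amine nitrogen was exchanged for an amide carbonyl, and the number fell by at least that amount. The other is an at least 20-fold higher number from compound 1 to compound 2 (1.31 log units; beyond the scatter). Both point the same way: the compounds carrying a methyl with a carbonyl on the amine nitrogen show the higher numbers, and compound 2 sits at a limit (the limit of > 200000 nM in this assay, at which 1 of the 3 values shown sits). Compound 4 keeps a methyl with a carbonyl on the amine nitrogen and is therefore expected to move upward, most likely by a modest to large step in this assay. Compound 4 is estimated at 100000 nM, within 25000 nM to 250000 nM, which means a 3.4-fold higher number from compound 3 to compound 4 (0.54 log units; beyond the scatter).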

Compound 4, half-maximal cytotoxic concentration: 14500 nM
The estimate for compound 4 lay 6.9-fold (0.84 log units) above the measured number, outside the stated range (below it).
By their numbers in this assay, from the lowest: compounds 1, 4 and 3 (each within the scatter of the next, the first and the last beyond it). At a limit, above all of these: compound 2.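

On the amine nitrogen, (carbamoylcarbonyl)methyl does not separate from either acyl group in this assay (first a 2.0-fold lower number from compound 3 to compound 4 (0.30 log units; within the scatter), then a 1.5-fold higher number from compound 1 to compound 4 (0.17 log units; within the scatter)), so a methyl bearing a carbonyl at this place does not by itself give the high number. The outcome instead turns on the end of the chain, where amino in place of methoxy on a carbonyl carbon makes a large difference (an at least 13-fold lower number from compound 2 to compound 4 (1.13 log units; beyond the scatter)). Compound 2 stands at a limit of the assay, not at a number: (the limit of > 200000 nM in this assay, at which 1 of the 4 values shown sits).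

On these data alone, whether a carboxylic acid or a methylamino group on that same carbonyl carbon would fall with compound 2 or with compound 4 stays open. So does whether a longer chain on the amine nitrogen would keep the number of compound 4 in this assay.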